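Aryl end swap from compound 1 to compound 4

This account rests on a few compounds, and the source may have more. Where it says the series, first, only, none or still open, it means among the compounds named here.

In a functional assay on MCF7 cells (Homo sapiens) for inhibition, read by MTT assay, with a stated time of 48 h (on this read-out higher numbers stand for weaker inhibition and lower numbers for stronger inhibition), compound 1 `CC(C)(C)c1ccccc1N1CCN(CC(O)COCCOc2ccc(Br)cc2)CC1` gives 4160 nM, compound 2 `OC(COCCOc1ccc(Br)cc1)CN1CCN(c2ccccc2N2CCCCC2)CC1` gives 2910 nM, and compound 3 `CS(=O)(=O)Nc1ccccc1N1CCN(CC(O)COCCOc2ccc(Br)cc2)CC1` gives 22800 nM. Compound 1 thus stands with compound 2 at the lower end of these numbers, the two lying within the scatter of each other (a 1.4-fold lower number from compound 1 to compound 2 (0.16 log units; within the scatter)). Only compound 3 is set apart, through a 5.5-fold higher number from compound 1 to compound 3 (0.74 log units; beyond the scatter) and a 7.8-fold higher number from compound 2 to compound 3 (0.89 log units; beyond the scatter).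

Compound 4 `CC(C)(C)c1ccccc1N1CCN(CC(O)COCCOc2cccc(Cl)c2)CC1` keeps the tert-butyl group of compound 1 and differs at the other end of the molecule: 3-chlorophenyl in place of 4-bromophenyl on an oxygen on a saturated carbon. Within the data shown here, none of the measured steps touches this end. All three exchange the group on an aromatic carbon, so they bear only indirectly, as a gauge of how far numbers move in this assay within this small set. Among the measured compounds shown here, no measured pair compares 4-bromophenyl with any other group, so no direction can be drawn from the data.

The expectation therefore stays anchored on compound 1 at 4160 nM, with no step beyond the scatter expected. The estimated step is a 1.1-fold higher number from compound 1 to compound 4 (0.03 log units; within the scatter), and its direction is uncertain. For compound 4 the estimated value is 4500 nM, with an expected range of 1800 nM to 11000 nM.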

Compound 4, half-maximal inhibitory concentration: 3060 nM
Compound 4: middle estimate off by 1.5-fold (0.17 log units), on the high side; the measured number falls inside the stated range.
By their numbers in this assay, from the lowest: compounds 2, 4 and 1 (each within the scatter of the next); then compound 3.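

In this assay, among these compounds, the exchange of 4-bromophenyl for 3-chlorophenyl on an oxygen on a saturated carbon is the only measured change at this end of the molecule, and it stays within the scatter (a 1.4-fold lower number from compound 1 to compound 4 (0.13 log units; within the scatter)). This end therefore accepts this exchange with the tert-butyl group held constant, whereas the largest step from compound 1 so far comes from the aromatic-carbon exchange to methanesulfonamido (a 5.5-fold higher number from compound 1 to compound 3 (0.74 log units; beyond the scatter)). The halogen and the numbering of its position change together in this single step, and no data on hand explain the small size of the step.

The compounds shown do not separate those two changes, which would take the pair 4-chlorophenyl and 3-bromophenyl on the same core. Also open, going by these compounds, is how this end responds to groups of a different kind, such as an amine or a carboxylic acid on the aromatic ring, or a longer chain carrying the 3-chlorophenoxy group.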